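A few compounds are considered here, and "the series" means these few. Any claim that something is new, unique, unknown or untested is made for them only; others in the source may bear on it.

Compound 1 `O=C1Nc2ccc(Br)cc2/C1=N/NC(=S)N/N=C/c1c(F)cccc1Cl` stands at the lower of the two numbers measured in a functional assay on COS-7 cells (Chlorocebus aethiops) for inhibition, read by MTT assay; on this read-out higher numbers stand for weaker inhibition and lower numbers for stronger inhibition: in this assay compound 1 gives 2560 nM, while compound 2 `O=C1Nc2ccc(Br)cc2/C1=N/NC(=S)N/N=C/c1ccc(Br)cc1` gives 5180 nM. For the measured compounds named here, the only measured step, a 2.0-fold higher number from compound 1 to compound 2 (0.31 log units; beyond the scatter), exchanges the group on a carbon with a double bond to nitrogen and leaves the bromo on the core untouched. Compound 3 `Cc1ccc2c(c1)/C(=N/NC(=S)N/N=C/c1c(F)cccc1Cl)C(=O)N2` differs from compound 1 on the core instead: methyl in place of bromo on an aromatic carbon. Going by the values given here, no measured pair changes this position, so the one recorded step does not bear directly on the exchange, and nothing in the data points toward a large shift in either direction. The step of a 1.2-fold higher number from compound 1 to compound 3 (0.07 log units; within the scatter) is therefore expected to remain within the usual scatter. Compound 3 is estimated to give 3000 nM in this assay, with a range from 1200 nM to 8000 nM.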

Compound 3, half-maximal inhibitory concentration: 2190 nM
Estimate against measurement, compound 3: 1.4-fold (0.14 log units) above, within the range that was stated.
By their numbers in this assay, from the lowest: compounds 3 and 1 (each within the scatter of the next); then compound 2.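

Read in this assay, the exchange of methyl for bromo gives a 1.2-fold lower number from compound 1 to compound 3 (0.07 log units; within the scatter), so compound 1 and compound 3 cannot be told apart on this read-out. For the compounds shown here, this is the first view of this position on the shared core, since the earlier step changed only the group at the other end of the molecule, and it shows that bromo is not needed here to keep the number at this level: methyl serves as well with the 2-chloro-6-fluorophenyl group in place. Nothing available explains this result.

On these data alone, it remains open whether an amine, a carboxylic acid or a longer chain at this position would stay as close to compound 1. As far as these compounds go, it is also open whether methyl and bromo would stay this close alongside the 4-bromophenyl group of compound 2.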